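The source may hold more compounds than are shown below. What is called first, only, known or untested is meant among the compounds shown, and "the series" means these compounds.

Working notes on the series.

Compound 3 `CCCNC(=O)C1C(C(=O)O)[C@@H]2CC[C@H]1O2`, compound 1 `CCCCNC(=O)C1C(C(=O)O)[C@@H]2CC[C@H]1O2` and compound 2 `CCCCCCCCCCNC(=O)C1C(C(=O)O)[C@@H]2CC[C@H]1O2` share one core and differ only in the chain on the amide nitrogen. In an ADME assay on A-431 cells (Homo sapiens) for cytotoxicity, read by MTT assay, with a stated time of 72 h (a lower number here means a stronger inhibitor of growth, a higher number a weaker inhibitor of growth), compound 3 gives 10000 nM, compound 1 gives 10000 nM and compound 2 gives 10000 nM. All three sit level at the digits shown: no change at the digits printed from compound 1 to compound 3 (within the scatter), no change at the digits printed from compound 1 to compound 2 (within the scatter) and no change at the digits printed from compound 2 to compound 3 (within the scatter). Compound 3 stands neither apart from nor above the others on these numbers.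

Compound 4 `O=C(O)C1C(C(=O)NCCCc2ccccc2)[C@H]2CC[C@@H]1O2` is reached from compound 3 by the change (phenyl in place of hydrogen on a saturated chain carbon, three bonds along the chain from an amide-type nitrogen). Among the compounds with values here, the same place on the chain is the one touched in the step from compound 1 to compound 3 and in the step from compound 2 to compound 3, both of which stayed within the scatter, and a hexyl added one bond further out in the step from compound 1 to compound 2 also left the number unchanged. Within the data shown here, none of the measured steps puts an aromatic group on this chain, so the phenyl has no direct precedent here; what is known is that lengthening or shortening the chain at this position did nothing.

Compound 4 is therefore expected to stay level, with the expected step of no change at the digits printed from compound 3 to compound 4 (within the scatter) within the scatter. The estimate for compound 4 in this assay is 10000 nM, with a range from 5000 nM to 20000 nM.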

Compound 4, concentration for 50% growth inhibition: 10000 nM
The estimate for compound 4 equals the measured number at the digits printed; measured number inside the range.
By their numbers in this assay, from the lowest: compounds 1, 2, 3 and 4 (each within the scatter of the next).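

In this assay phenyl in place of hydrogen on a saturated chain carbon, three bonds along the chain from an amide-type nitrogen, gives no change at the digits printed from compound 3 to compound 4 (within the scatter) and so extends the reading at this place from saturated chains to a six-membered aromatic ring of carbon only. Phenyl in place of heptyl gives no change at the digits printed from compound 2 to compound 4 (within the scatter) and phenyl in place of methyl gives no change at the digits printed from compound 1 to compound 4 (within the scatter) in the same assay, which leaves the aromatic compound level with all three chain compounds. Nothing available on these compounds offers a reason for this result.

The four compounds leave open whether a substituent on the phenyl ring, such as an amine, a hydroxyl or a carboxylic acid, would separate from the others in this assay at this place. They also leave open what replacing the carboxylic acid on the shared core with an ester or an amide would give, since that group stands unchanged in all four compounds.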